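A 4-fluorobenzyl group replaces 4-methylphenyl on a sulfur

This account rests on a few compounds, and the source may have more. Where it says the series, first, only, none or still open, it means among the compounds named here.

- compound 1 `O=C(/C(=C\c1ccc(Cl)cc1)SCc1ccc(F)cc1)c1ccc(Cl)cc1` gives 10000 nM
- compound 2 `Cc1ccc(S/C(=C/c2c[nH]c3ccc(Br)cc23)C(=O)c2ccc(Cl)cc2)cc1` gives 1000 nM

In a functional assay on DU-145 cells (Homo sapiens) for inhibition, read by trypan blue exclusion, with a stated time of 96 h (a lower number here means a stronger inhibitor of growth, a higher number a weaker inhibitor of growth), compound 2 holds the lower of the two numbers at 1000 nM and is the stronger inhibitor of growth, while compound 1 reads 10000 nM on the far side of the scatter. Compound 3 `O=C(/C(=C\c1c[nH]c2ccc(Br)cc12)SCc1ccc(F)cc1)c1ccc(Cl)cc1` carries 4-fluorobenzyl in place of 4-methylphenyl on a sulfur. Among the measured compounds shown here, no step between measured compounds shows this change alone, so its size cannot be read directly from the data. For the measured compounds named here, the only other reading, compound 1 at 10000 nM in the same test, leaves room for a somewhat higher number. The expected step of a 1.5-fold higher number from compound 2 to compound 3 (0.18 log units; within the scatter) is small and upward, and it is not expected to pass beyond the scatter. In this assay compound 3 is estimated at 1500 nM with an expected range from 300 nM to 6000 nM in this test.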

Compound 3, concentration for 50% growth inhibition: 50000 nM
For compound 3 the middle estimate is 33-fold (1.52 log units) below the measured one, outside the stated range (above it).
By their numbers in this assay, from the lowest: compound 2; then compound 1; then compound 3.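

At the sulfur, 4-fluorobenzyl in place of 4-methylphenyl is far from a neutral swap in this assay: with 5-bromo-1H-indol-3-yl held fixed, the change gives a 50-fold higher number from compound 2 to compound 3 (1.70 log units; beyond the scatter) and so marks this position as sensitive to the group it carries. With 4-fluorobenzyl held on the sulfur, 5-bromo-1H-indol-3-yl in place of 4-chlorophenyl gives a 5.0-fold higher number from compound 1 to compound 3 (0.70 log units; beyond the scatter) and thus brings no gain in that setting. Nothing available here bears on the reason for either step.

Still open, from the compounds shown here alone, is which part of the change at the sulfur carries the loss, which an unsubstituted benzyl or a 4-fluorophenyl group there could separate. Also open, going by these compounds, is how 5-bromo-1H-indol-3-yl compares with 4-chlorophenyl when 4-methylphenyl sits on the sulfur.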